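Bromo for fluoro on a shared hydrazone-thiazoline core

The source may report more compounds than this note shows. Statements on the series, on what has been measured and on what is new or still open speak of the compounds shown alone.

Measured so far:
compound 1, `O=C(CSc1ncccn1)N/N=c1/scc(-c2ccc(Br)cc2)n1-c1ccccc1`, 273 ug/mL
compound 2, `Cc1nnc(SCC(=O)N/N=c2/scc(-c3ccc(F)cc3)n2-c2ccccc2)s1`, 383 ug/mL

Both compounds were tested in an ADME assay on NIH3T3 cells (Mus musculus) for cytotoxicity, read by MTT assay, with a stated time of 24 h; a higher number here means a weaker inhibitor, a lower number a stronger inhibitor. Compound 1 gives 273 ug/mL and compound 2 gives 383 ug/mL; compound 2 has the higher of the two numbers, but the gap to compound 1 lies within the scatter of repeated measurements, so the two cannot be told apart on these data.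

Compound 3, `Cc1nnc(SCC(=O)N/N=c2/scc(-c3ccc(Br)cc3)n2-c2ccccc2)s1`, has not yet been measured. It differs from compound 2 in one place: bromo in place of fluoro on an aromatic carbon. Compound 3 therefore carries the same bromo group as compound 1 while keeping the rest of compound 2 unchanged.

For the measured compounds named here, no step between measured compounds is known for this exact change. Since compound 1, which already carries bromo, gives 273 ug/mL, the step from compound 2 to compound 3 is expected to be small, at most a modest move towards a lower number, and quite possibly none beyond the scatter. In this assay compound 3 is expected to give about 320 ug/mL, within a range from 180 ug/mL to 560 ug/mL, which corresponds to an expected step of a 1.2-fold lower number from compound 2 to compound 3 (0.08 log units; within the scatter).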

Compound 3, half-maximal inhibitory concentration: 55 ug/mL
Compound 3: middle estimate off by 5.8-fold (0.76 log units), on the high side; measured number outside the range, below it.
By their numbers in this assay, from the lowest: compound 3; then compounds 1 and 2 (each within the scatter of the next).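

In this assay, the exchange of fluoro for bromo on the aromatic carbon para to a large group gives a 7.0-fold lower number from compound 2 to compound 3 (0.84 log units; beyond the scatter), a step beyond the scatter, so this position responds clearly to a swap of one heavy atom for another, with no ring, hydrogen-bond donor, hydrogen-bond acceptor or net charge entering or leaving. With bromo held fixed, 5-methyl-1,3,4-thiadiazol-2-yl in place of pyrimidin-2-yl on the sulfur gives a 5.0-fold lower number from compound 1 to compound 3 (0.70 log units; beyond the scatter), also beyond the scatter, so bromo alone does not set the number and the group on the sulfur matters as well. Nothing available here explains why either change has this effect.

Whether the gain from bromo depends on the 5-methyl-1,3,4-thiadiazol-2-yl group remains open, since the compounds shown offer only one fluoro-to-bromo pair and that pair carries this group on the sulfur. Also open, as far as these compounds go, is how chloro, methyl or an amine would compare with bromo at the same aromatic carbon, and so whether the step is particular to bromo or extends to other groups.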